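The source may hold more compounds than are shown below. What is called first, only, known or untested is meant among the compounds shown, and "the series" means these compounds.

Within the data shown here, compound 3 `NC(=O)[C@@H](CCC(F)(F)F)N(C[C@H]1CCCCO1)S(=O)(=O)c1ccc(Cl)cc1` gives 4.3 in a physicochemical assay for lipophilicity, read by HPLC, measured as octanol-water partition, at pH 7.4 (a lower number here means a more polar compound, a higher number a more lipophilic compound), the highest of the three numbers measured so far. Compound 1 `CC1(C)C[C@H](CN([C@H](CCC(F)(F)F)C(N)=O)S(=O)(=O)c2ccc(Cl)cc2)O1` gives 3.8 and compound 2 `CC1(C)CO[C@H]1CN([C@H](CCC(F)(F)F)C(N)=O)S(=O)(=O)c1ccc(Cl)cc1` gives 3.8; the steps of a number 0.50 log units higher from compound 1 to compound 3 (beyond the scatter) and a number 0.50 log units higher from compound 2 to compound 3 (beyond the scatter) both run upward, whereas no change at the digits printed from compound 1 to compound 2 (within the scatter). Compound 4 `NC(=O)[C@@H](CCC(F)(F)F)N(C[C@@H]1CCCOC1)S(=O)(=O)c1ccc(Cl)cc1` differs from compound 3 as follows: oxan-3-yl in place of oxan-2-yl on a saturated chain carbon bound to a sulfonamide nitrogen. No measured step keeps the same atoms while joining them differently, so the steps shown bear only loosely on this change; the same ring is kept, and no step beyond the scatter is expected in this assay. Compound 4 is therefore estimated at 4.2, with a range of 3.9 to 4.5, which means an expected step of a number 0.10 log units lower from compound 3 to compound 4 (within the scatter).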

Compound 4, distribution coefficient: 3.7
Estimate against measurement, compound 4: 0.50 log units above; the whole stated range lies above it.
By their numbers in this assay, from the lowest: compounds 4, 1 and 2 (each within the scatter of the next); then compound 3.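

In this assay, moving the attachment point on the same ring is enough to shift the number at this position: a number 0.60 log units lower from compound 3 to compound 4 (beyond the scatter). Oxan-3-yl stands within the scatter of both dimethyloxetanyl groups, with a number 0.10 log units lower from compound 2 to compound 4 (within the scatter) and a number 0.10 log units lower from compound 1 to compound 4 (within the scatter), so among these four compounds only the oxan-2-yl of compound 3 stands apart. No measurement at hand accounts for the difference between the two oxanyl attachments.

As far as these compounds go, whether oxan-4-yl would read with compound 3 or with compound 4 remains open. So does the reading for a ring amine such as piperidin-3-yl on the same saturated chain carbon.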